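Notes on the step from compound 3 to compound 4

A few compounds are considered here, and "the series" means these few. Any claim that something is new, unique, unknown or untested is made for them only; others in the source may bear on it.

In a functional assay on SW620/5-FU cells (Homo sapiens) for cytotoxicity, read by MTT assay, with a stated time of 48 h, in the presence of a further agent that is not named here (a lower number here means that less compound is needed, a higher number that more compound is needed for the effect), compound 1 (`Cn1ncc2c(-c3ccc(F)cc3)cc(NNC(=O)Nc3cc(Cl)cc(Cl)c3)nc21`) gives 54300 nM, compound 2 (`Cn1ncc2c(-c3ccc(F)cc3)cc(NNC(=O)Nc3cc(Cl)nc(OCCF)c3)nc21`) gives 29300 nM and compound 3 (`COc1cc(NC(=O)NNc2cc(-c3ccc(F)cc3)c3cnn(C)c3n2)cc(Cl)n1`) gives 24100 nM. Compound 3 separates from compound 1 only, with a 2.3-fold lower number from compound 1 to compound 3 (0.35 log units; beyond the scatter). By contrast, a 1.2-fold lower number from compound 2 to compound 3 (0.08 log units; within the scatter) and a 1.9-fold lower number from compound 1 to compound 2 (0.27 log units; within the scatter) both stay within the scatter.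

Compound 4 (`Cn1ncc2c(-c3ccc(F)cc3)cc(NNC(=O)Nc3cc(F)cc(F)c3)nc21`) differs from compound 3 by 3,5-difluorophenyl in place of 2-chloro-6-methoxypyridin-4-yl on an amide-type nitrogen. Among the compounds with values here, no measured compound carries 3,5-difluorophenyl, so the closest guide is the modest step of a 2.3-fold lower number from compound 1 to compound 3 (0.35 log units; beyond the scatter), which installs 2-chloro-6-methoxypyridin-4-yl in place of 3,5-dichlorophenyl. Leaving that pyridinyl group for a phenyl group with two halogens is therefore expected to run the other way in this assay, with a rise no larger than that step and possibly within the scatter. The expected change is a 1.7-fold higher number from compound 3 to compound 4 (0.24 log units; within the scatter). Compound 4 is estimated at 42000 nM, with an expected range of 18000 nM to 90000 nM.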

Compound 4, half-maximal effective concentration: 47400 nM
For compound 4 the middle estimate is 1.1-fold (0.05 log units) below the measured one, and the stated range covers the measured number.
By their numbers in this assay, from the lowest: compounds 3, 2, 4 and 1 (each within the scatter of the next, the first and the last beyond it).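

In this assay, the step from 3,5-dichlorophenyl to 3,5-difluorophenyl on the amide-type nitrogen, a 1.1-fold lower number from compound 1 to compound 4 (0.06 log units; within the scatter), leaves the two halogen-bearing phenyl compounds indistinguishable. Within the data shown here, compound 4 also stays within the scatter of both pyridinyl compounds, with a 2.0-fold higher number from compound 3 to compound 4 (0.29 log units; within the scatter) and a 1.6-fold higher number from compound 2 to compound 4 (0.21 log units; within the scatter), so the one step beyond the scatter, from compound 1 to compound 3, does not extend to a general separation of pyridinyl from phenyl groups at this position. No supporting measurement bears on these steps.

As far as these compounds go, whether an amine or a carboxylic acid in place of the halogens on the phenyl group would move the number beyond the scatter remains open. The same holds for a longer alkoxy chain on the pyridinyl group.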